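A Trifluoromethylphenyl Analogue Awaiting Its Cytotoxicity Number

The compounds below may be only part of what the source reports. "The series", "measured", "known", "first", "only" and "open" are said of these compounds alone.

Compound 1 `C=C1C[C@]23C[C@@]1(O)CC[C@H]2c1ccc(O)c(C)c1[C@@H]3Cn1cc(-c2ccccn2)nn1` was tested in a functional assay on SMMC-7721 cells (Homo sapiens) for cytotoxicity, read by MTT assay, with a stated time of 4 days (on this read-out higher numbers stand for weaker inhibition and lower numbers for stronger inhibition), and gave > 20000 nM, which is a limit of the assay rather than a number. Two related compounds carrying a different group on the five-membered aromatic ring with 3 nitrogen, and a different form of the shared core, were measured in the same way. Compound 2 `Cc1c(O)ccc2c1[C@H](Cn1cc(-c3ccc(F)cc3)nn1)[C@@]13CC(=O)[C@@](C)(CC[C@@H]21)C3` gave > 20000 nM in this assay, again a limit. Compound 3 `Cc1c(O)ccc2c1[C@H](Cn1cc(-c3ccc(Cl)cc3)nn1)[C@@]13CC(=O)[C@@](C)(CC[C@@H]21)C3` gave > 20000 nM in this assay, also a limit. The change from compound 2 to compound 3, chloro in place of fluoro on an aromatic carbon, is therefore a step that the two limits leave unreadable from compound 2 to compound 3. Compound 4 `C=C1C[C@]23C[C@@]1(O)CC[C@H]2c1ccc(O)c(C)c1[C@@H]3Cn1cc(-c2ccc(C(F)(F)F)cc2)nn1` is compound 1 with 4-(trifluoromethyl)phenyl in place of pyridin-2-yl on an aromatic carbon. Within the data shown here, the only evidence that bears on this change is the limit of > 20000 nM in this assay, at which 3 of the 3 values shown sit, so no measured step tells how far exchanging the group on that ring can move the read-out. Compound 4 is expected to remain near the limit because of the limit of > 20000 nM in this assay, at which 3 of the 3 values shown sit, with an estimated value of 25000 nM and a range from 8000 nM to 80000 nM. The step from compound 1 to compound 4 is accordingly estimated as a step that the limit leaves unreadable from compound 1 to compound 4, none beyond the scatter.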

Compound 4, half-maximal inhibitory concentration: > 20000 nM
Compound 4 was reported as a limit (the forecaster's own chance of this, stated with the estimate: 80%); the middle value does not contradict the limit.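

Among these compounds, compound 1 and compound 4 both stand at a limit of the assay, so exchanging pyridin-2-yl for 4-(trifluoromethyl)phenyl gives no step that can be read. What stays open is whether any group on that ring, or any form of the shared core, can give a readable number in this assay: the limit of > 20000 nM in this assay, at which 4 of the 4 values shown sit.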